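This account rests on a few compounds, and the source may have more. Where it says the series, first, only, none or still open, it means among the compounds named here.

Measured so far:
compound 1, `Cc1ccc(C(=O)Nc2cn3ncnc3c(CN3CCN(C(=O)CCC(F)(F)F)[C@@H](C)C3)c2C)cn1`: < 10 mL.min-1.g-1
compound 2, `Cc1ccc(C(=O)Nc2cn3ncnc3c(CN3CCN(C(=O)C4CCC(F)(F)C4)[C@@H](C)C3)c2C)cn1`: < 10 mL.min-1.g-1
compound 3, `Cc1ccc(C(=O)Nc2cn3ncnc3c(CN3CCN(C(=O)CC(C)C)[C@@H](C)C3)c2C)cn1`: 20 mL.min-1.g-1

In an ADME assay on microsomes from liver (Homo sapiens) for metabolic stability (on this read-out lower numbers stand for slow clearance and higher numbers for fast clearance), compound 1 gives only a limit, < 10 mL.min-1.g-1. Compound 2 likewise returns only a limit, < 10 mL.min-1.g-1. Going by the values given here, compound 3, at 20 mL.min-1.g-1 in this assay, carries the only number in the set. Compound 4, `Cc1ccc(C(=O)Nc2cn3ncnc3c(CN3CCN(C(=O)CC(C(F)(F)F)C(F)(F)F)[C@@H](C)C3)c2C)cn1`, is not yet measured. It differs from compound 3 as follows: 2,2,2-trifluoro-1-(trifluoromethyl)ethyl in place of isopropyl on a saturated chain carbon bound to a carbonyl carbon. The measured steps bearing on it run the other way: an at least 2.0-fold higher number from compound 1 to compound 3 (0.30 log units; that floor lies within the scatter), and an at least 2.0-fold higher number from compound 2 to compound 3 (0.30 log units; that floor lies within the scatter). Compound 4 pushes the chain in the opposite direction to that taken by compound 3, so a lower number is expected from compound 3 to compound 4, a 2.5-fold lower number from compound 3 to compound 4 (0.40 log units; beyond the scatter). A limit reading is plausible, given (the limit of < 10 mL.min-1.g-1 in this assay, at which 2 of the 3 values shown sit). For compound 4 the estimate is 8 mL.min-1.g-1, with a range of 3 mL.min-1.g-1 to 18 mL.min-1.g-1.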

Compound 4, intrinsic clearance in microsomes: < 10 mL.min-1.g-1
Compound 4: only a limit was reported (the forecaster's own chance of this, stated with the estimate: 60%); the middle value is on the limit's open side.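

At the saturated chain carbon bound to a carbonyl carbon, 2,2,2-trifluoro-1-(trifluoromethyl)ethyl in place of isopropyl gives, in this assay, an at least 2.0-fold lower number from compound 3 to compound 4 (0.30 log units; that floor lies within the scatter). Compound 4 reports only a limit, so the true size of this step stays hidden, and the steps from compound 1 and compound 2 to compound 4 cannot be read. The branched chain now joins the unbranched and ring-bearing fluorinated acyl groups at one floor: the limit of < 10 mL.min-1.g-1 in this assay, at which 3 of the 4 values shown sit.

No order among compound 1, compound 2 and compound 4 can be drawn. From the compounds shown here alone, how an ether chain or an amine at this place would read remains open.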